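Working notes: from compound 2 to compound 3

The source may hold more compounds than are shown below. What is called first, only, known or untested is meant among the compounds shown, and "the series" means these compounds.

Measured in an assay on isolated protein (artery, Oryctolagus cuniculus) with Substance-P receptor (Homo sapiens) as the target; a lower number here means tighter binding, a higher number weaker binding:
- compound 1 `CS(=O)(=O)N1CCN(C2CN(CCC3(c4ccc(Cl)c(Cl)c4)CCC(=O)N(Cc4ccccc4)C3)C2)CC1`: compound 1 gives 0.631 nM
- compound 2 `CNS(=O)(=O)N1CCN(C2CN(CCC3(c4ccc(Cl)c(Cl)c4)CCC(=O)N(CC4CC4)C3)C2)CC1`: compound 2 gives 3.16 nM

Compound 2 has the higher of the two numbers in this assay; compound 1, the nearest and only other measured compound, sits at a lower number, a gap beyond the usual scatter. For the measured compounds named here, the two differ in more than one place, so their values are only read side by side and no single step is drawn from them.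

Compound 3 `O=C1CCN(C2CN(CCC3(c4ccc(Cl)c(Cl)c4)CCC(=O)N(CC4CC4)C3)C2)CC1` has not been measured. Relative to compound 2 the change is 4-oxopiperidin-1-yl in place of 4-(methylsulfamoyl)piperazin-1-yl on a saturated ring carbon. Going by the values given here, no measured pair shows this change, so the expectation rests on compound 2 alone. A modest step to a higher number in this assay is expected, of about a 1.9-fold higher number from compound 2 to compound 3 (0.28 log units; within the scatter), though a result within the scatter would not surprise.

For compound 3 the estimated value in this assay is 6 nM, with a range from 1.5 nM to 25 nM.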

Compound 3, dissociation constant: 1.26 nM
The estimate for compound 3 lay 4.8-fold (0.68 log units) above the measured number; measured number below the stated range.
By their numbers in this assay, from the lowest: compounds 1 and 3 (each within the scatter of the next); then compound 2.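

In this assay, for the compounds shown here, 4-oxopiperidin-1-yl in place of 4-(methylsulfamoyl)piperazin-1-yl on a saturated ring carbon of the four-membered ring gives a 2.5-fold lower number from compound 2 to compound 3 (0.40 log units; beyond the scatter), the first single change that can be read on its own, and it shows that this position affects the binding number beyond the scatter. Tight binding at this position holds without the methylsulfamoyl unit, the second ring nitrogen or the hydrogen-bond donor counted on the leaving group, at least in this one pair. Nothing at hand bears on the reason for this step.

This step does not separate the loss of the methylsulfamoyl unit from the arrival of the ring carbonyl, and it does not show whether the same exchange would hold with the other substituent carried by compound 1. A 4-hydroxypiperidin-1-yl or 4-aminopiperidin-1-yl group at the same place would show whether the carbonyl itself matters to the number, and a piperidine bearing a carboxylic acid would extend the comparison to a charged group.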